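The source may report more compounds than this note shows. Statements on the series, on what has been measured and on what is new or still open speak of the compounds shown alone.

Series notes. In a functional assay on Bel-7402 cells (Homo sapiens) for cytotoxicity, read by MTT assay (a lower number here means a stronger inhibitor, a higher number a weaker inhibitor), compound 1 `COc1cccc(/C=C/C(=O)c2sc(Nc3cccc(C)c3)nc2C)c1` reports only a limit, > 25000 nM, and not a number. Compound 2 `Cc1ccc(Nc2nc(C)c(C(=O)/C=C/c3ccc(Cl)cc3)s2)cc1` likewise gives only the limit of > 25000 nM. Compound 3 `Cc1nc(Nc2ccc(Cl)cc2)sc1C(=O)/C=C/c1ccc(Cl)cc1` also gives only the limit of > 25000 nM. Among the compounds with values here, the single one-point step among the measured compounds, a step that the two limits leave unreadable from compound 2 to compound 3, has no readable size, since both of its ends are limits; the whole measured picture is the limit of > 25000 nM in this assay, at which 3 of the 3 values shown sit. Compound 4 `Cc1cccc(Nc2nc(C)c(C(=O)/C=C/c3ccc(Cl)cc3)s2)c1` differs from compound 3 by 3-methylphenyl in place of 4-chlorophenyl on a nitrogen on an aromatic ring, that is, (4-chlorophenyl)amino to (3-methylphenyl)amino. Within the data shown here, no measured step carries a readable size, so no direction beyond the scatter is predicted in this assay. Compound 4 is expected to remain at the limit, estimated at 30000 nM with a range from 10000 nM to 100000 nM. The expected step is therefore a step that the limit leaves unreadable from compound 3 to compound 4.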

Compound 4, half-maximal inhibitory concentration: > 25000 nM
Compound 4: only a limit was reported; the forecaster's own chance of this, stated with the estimate: 85%; the middle value is on the limit's open side.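

No new step can be read from compound 4 to compound 1, compound 2 or compound 3 in this assay, as each value is only a limit: the limit of > 25000 nM in this assay, at which 4 of the 4 values shown sit. The compounds shown leave open whether any change on the shared core alters cytotoxicity at all.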